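This account rests on a few compounds, and the source may have more. Where it says the series, first, only, none or still open, it means among the compounds named here.

Measured compounds, with their numbers in an assay on isolated protein for binding affinity to Leucine-rich repeat serine/threonine-protein kinase 2 variant G2019S (Homo sapiens), read by TR-FRET and LanthaScreen, with a stated time of 2 h; on this read-out higher numbers stand for weaker inhibition and lower numbers for stronger inhibition:
- compound 1, `CN(C)c1c(C#N)c2c(N)ncnc2n1C`, gives 259 nM
- compound 2, `C[C@@H]1CCCN1c1c(C#N)c2c(N)nc(Nc3cnn(C)c3)cc2n1C`, gives 794 nM
- compound 3, `C[C@@H]1CCCN1c1c(C(N)=O)c2c(N)ncnc2n1C`, gives 154 nM

Among these three numbers compound 1 holds the second highest. Its nearest neighbour is compound 3, whose number is lower but still within the usual scatter of repeated measurements, so on this read-out the two cannot be told apart. Compound 2 sits furthest from compound 1, with a higher number that lies beyond the scatter. No two of the measured compounds differ in only one place, so no single-point step can be read off from the measured set.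

Compound 4, `Cn1c(N)c(C#N)c2c(N)ncnc21`, has not yet been measured in this assay. Relative to compound 1 the change is amino in place of dimethylamino on an aromatic carbon. The shared core is otherwise kept. Going by the values given here, since no comparable step among the measured compounds is available, the size of this step can only be guessed: a modest shift toward a higher number in this assay is expected, with the range left wide enough to cover no change beyond the scatter. Compound 4 is estimated at 400 nM, between 120 nM and 1300 nM, which amounts to the expected step of a 1.5-fold higher number from compound 1 to compound 4 (0.19 log units; within the scatter).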

Compound 4, inhibition constant: 589 nM
Compound 4: middle estimate off by 1.5-fold (0.17 log units), on the low side, within the range that was stated.
By their numbers in this assay, from the lowest: compounds 3 and 1 (each within the scatter of the next); then compounds 4 and 2 (each within the scatter of the next).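

Going by these compounds alone, the first comparison that differs in one place falls on the aromatic carbon next to the ring nitrogen: in this assay, amino in place of dimethylamino gives a 2.3-fold higher number from compound 1 to compound 4 (0.36 log units; beyond the scatter). The read-out therefore responds to the group at this position, favouring dimethylamino over amino, although the step is modest and both compounds retain measurable numbers. No measurement is available that explains the step or separates the loss of the two methyl groups from the gain of a hydrogen-bond donor.

Methylamino, which would keep one of the two methyl groups, could show whether the number follows compound 1 or compound 4, while diethylamino or azetidine could show whether larger groups at this carbon give lower numbers than dimethylamino. From the compounds shown here alone, the step is also known only with the nitrile in place and without the further substituent carried by compound 2, so its size alongside the carboxamide of compound 3 or on the more elaborate core of compound 2 remains open.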